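Ester cleavage to free acid in the series

A few compounds are considered here, and "the series" means these few. Any claim that something is new, unique, unknown or untested is made for them only; others in the source may bear on it.

Compound 3 `C/C=C1/[C@H](O[C@@H]2O[C@H](CO)[C@@H](O)[C@H](O)[C@H]2O)OC=C(C(=O)OC)[C@H]1CC(=O)OCc1ccccc1` is measured in a functional assay on SK-BR-3 cells (Homo sapiens) for antiproliferative activity, read by MTT assay, with a stated time of 72 h; on this read-out higher numbers stand for weaker inhibition and lower numbers for stronger inhibition. Its value there is a limit of the assay: compound 3 gives > 15000 nM. Compound 1 `C=C(C)CCOC(=O)C[C@@H]1C(C(=O)OC)=CO[C@@H](O[C@@H]2O[C@H](CO)[C@@H](O)[C@H](O)[C@H]2O)/C1=C/C` also returns a limit, at > 15000 nM. Compound 2 `C/C=C1/[C@H](O[C@@H]2O[C@H](CO)[C@@H](O)[C@H](O)[C@H]2O)OC=C(C(=O)OC)[C@H]1CC(=O)OCC` likewise sits at a limit, > 15000 nM. Compound 3 thus stands level with the other two, all at the limit of > 15000 nM in this assay, at which 3 of the 3 values shown sit. The steps a step that the two limits leave unreadable from compound 1 to compound 2, a step that the two limits leave unreadable from compound 1 to compound 3 and a step that the two limits leave unreadable from compound 2 to compound 3 are therefore unreadable in size. Compound 4 `C/C=C1/[C@H](O[C@@H]2O[C@H](CO)[C@@H](O)[C@H](O)[C@H]2O)OC=C(C(=O)OC)[C@H]1CC(=O)O` differs from compound 3 by hydrogen in place of benzyl on an oxygen next to a carbonyl group. Among the compounds with values here, since no measured step has a readable size, no direction beyond the scatter can be expected in this assay from this change. The expected step is estimated as a step that the limit leaves unreadable from compound 3 to compound 4. Compound 4 is expected to give about 20000 nM, within 10000 nM to 60000 nM, most probably reported once more as a limit.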

Compound 4, half-maximal inhibitory concentration: > 15000 nM
Compound 4: no number, only a limit; the forecaster's own chance of this, stated with the estimate: 90%; the middle value does not contradict the limit.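

Compound 4 joins compound 1, compound 2 and compound 3 at a limit, so no new step can be read in this assay: the limit of > 15000 nM in this assay, at which 4 of the 4 values shown sit.

The compounds shown leave open which change to the shared core would give a measurable value.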